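From compound 2 to compound 4: a shortened aryl arm

The source may hold more compounds than are shown below. What is called first, only, known or untested is meant among the compounds shown, and "the series" means these compounds.

Going by the values given here, compound 2 `COC(=O)/C=C/c1cccc(N(Cc2ccc(/C=C/c3cccc(C(F)(F)F)c3)cc2)C(=O)C(C)C)c1` gives 267 nM in an assay on isolated protein with Bile acid receptor (Homo sapiens) as the target (a lower number here means that less compound is needed, a higher number that more compound is needed for the effect), the lowest of the three numbers so far. Compound 3 `COC(=O)/C=C/c1cccc(N(Cc2ccc(/C=C/c3ccccc3F)cc2)C(=O)NC(C)C)c1` gives 431 nM in this assay, within the scatter of compound 2. Compound 1 `COC(=O)/C=C/c1cccc(N(Cc2ccc(/C=C/c3cc(C(F)(F)F)cc(C(F)(F)F)c3)cc2)C(=O)C(C)C)c1` gives 1950 nM in this assay; the step of a 7.3-fold lower number from compound 1 to compound 2 (0.86 log units; beyond the scatter) is the only one that separates two measured compounds beyond the scatter.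

Compound 4 `COC(=O)/C=C/c1cccc(N(Cc2ccc(-c3ccc(C)cc3)cc2)C(=O)C(C)C)c1` differs from compound 2 in one place: 4-methylphenyl in place of 2-(3-(trifluoromethyl)phenyl)ethenyl on an aromatic carbon. Among the compounds with values here, no measured pair bears directly on this exchange; the one measured step, a 7.3-fold lower number from compound 1 to compound 2 (0.86 log units; beyond the scatter), concerns only a trifluoromethyl and keeps the ethenyl bridge, so it gives a scale for a smaller change than this one. The loss of the bridge and of the trifluoromethyl together is larger than anything measured, so the expected step is uncertain in both directions. On balance a weaker result is expected for compound 4, an estimated 5.6-fold higher number from compound 2 to compound 4 (0.75 log units; beyond the scatter), because compound 2 with 267 nM is the lowest number reached and every other change recorded has raised it. The estimate for compound 4 is 1500 nM, in the range 300 nM to 8000 nM.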

Compound 4, half-maximal effective concentration: 118 nM
For compound 4 the middle estimate is 13-fold (1.10 log units) above the measured one; the measured number lies below the stated range.
By their numbers in this assay, from the lowest: compound 4; then compounds 2 and 3 (each within the scatter of the next); then compound 1.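

In this assay, the exchange of 2-(3-(trifluoromethyl)phenyl)ethenyl for 4-methylphenyl gives a 2.3-fold lower number from compound 2 to compound 4 (0.35 log units; beyond the scatter), so this position on the aromatic ring accepts a group with no double bond outside aromatic rings and fewer heavy atoms, with one aromatic ring kept. The earlier step changed only a trifluoromethyl on an arm that kept the ethenyl bridge, whereas this exchange removes the bridge and the trifluoromethyl and adds a methyl at once, so the step cannot be assigned to any one of these changes. The data shown offer no explanation for the step.

From the compounds shown here alone, it remains open whether the methyl contributes at all, which a plain phenyl at this position would test, or whether a trifluoromethyl would be tolerated on the directly attached ring. The effect of a more polar substituent there, such as an amine or a carboxylic acid, is also unresolved.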